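Nitro on the furan ring: a small step in rat paw edema

This account rests on a few compounds, and the source may have more. Where it says the series, first, only, none or still open, it means among the compounds named here.

Measured so far:
compound 1 `COc1ccc(Cl)c(-c2nnc3n2NC(c2ccco2)S3)c1` gives 18.7%
compound 2 `Cc1occc1-c1nnc2n1NC(c1ccco1)S2` gives 21.6%
compound 3 `COc1ccc(Cl)c(-c2nnc3n2NC(c2ccc([N+](=O)[O-])o2)S3)c1` gives 18.5%

All three were tested in a functional assay on the whole organism (strain Wistar Albino) for inhibition, with Rattus norvegicus as the target, read by paw edema, with a stated time of 2 h, at a dose of 20 mg/kg; on this read-out higher numbers stand for more inhibition at the one dose given (going by the name of the read-out) and lower numbers for less inhibition. Compounds 1 and 3 share one core, and compound 3 carries the change (nitro in place of hydrogen on an aromatic carbon). The step that this change made is a number 0.2 percentage points lower from compound 1 to compound 3 (within the scatter), so the two numbers lie within the scatter of each other and no ordering between compound 1 and compound 3 can be read from them.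

Compound 2 has a different core from compound 1; the difference between the two cores is not broken down here. The three measured values all lie within the scatter of one another, so none of them can be called stronger or weaker.

Compound 4 `Cc1occc1-c1nnc2n1NC(c1ccc([N+](=O)[O-])o1)S2` has not yet been measured. It relates to compound 2 exactly as compound 3 relates to compound 1, through the change (nitro in place of hydrogen on an aromatic carbon), made at the same place. For the measured compounds named here, the only guide is the single earlier example of this change, which made the step of a number 0.2 percentage points lower from compound 1 to compound 3 (within the scatter). Going by the values given here, on that basis the step from compound 2 to compound 4 is expected to be about as small, a number 0.6 percentage points lower from compound 2 to compound 4 (within the scatter), because the one measured instance, a number 0.2 percentage points lower from compound 1 to compound 3 (within the scatter), stayed within the scatter. Compound 4 is therefore estimated to give about 21% in this assay, expected to fall between 12% and 30%. This rests on one pair only, and a second example could read differently.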

Compound 4, a percentage reported as inhibition, in the whole organism at one dose (the size of the read-out at that dose, not a potency): 18.1%
Compound 4: middle estimate off by 2.9 percentage points, on the high side; the measured number falls inside the stated range.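

In this assay, nitro in place of hydrogen on an aromatic carbon of the second core gave a number 3.5 percentage points lower from compound 2 to compound 4 (within the scatter). Set beside the earlier example, the two steps are no further apart than repeated measurements of this kind would be expected to scatter: the same change on two cores in this assay, a number 0.2 percentage points lower (within the scatter) from compound 1 to compound 3 and a number 3.5 percentage points lower (within the scatter) from compound 2 to compound 4, 3.3 percentage points apart, within the scatter of two such steps So in both pairs the change left the reading within the scatter, and nothing here suggests that the two cores respond to it differently, but this does not show that they respond alike or that the nitro group has no effect at all, as a small real effect could lie hidden in the scatter and two pairs are a thin basis for any rule about the series.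

The compounds shown leave open whether a different group at this same place on the ring, such as an amine, a carboxylic acid or a longer chain, would give a number clearly apart from the others. They also leave open whether the nitro change would still stay within the scatter on a third core, or at another dose or reading time in the same kind of test.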